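The compounds below may be only part of what the source reports. "The series", "measured", "known", "first", "only" and "open" are said of these compounds alone.

For the measured compounds named here, compound 2 `Cn1nc(C(F)(F)F)cc1C(=O)Nc1ccc(S(=O)(=O)n2ccc3ccccc32)cc1` is the one compound here with a number: in an ADME assay on Vero cells (Chlorocebus sabaeus) for cytotoxicity, read by MTT assay (on this read-out lower numbers stand for higher toxicity in this test and higher numbers for lower toxicity in this test), compound 2 gives 13000 nM. Compound 1 `O=C(Nc1ccc(S(=O)(=O)N2CCCC2)cc1)c1nc2ccccc2s1` gives > 300000 nM in this assay, and that value is a limit of the assay rather than a number. Compound 2 thus stands apart from the limit of > 300000 nM in this assay, at which 1 of the 2 values shown sits. Compound 3 `Cn1nc(C(F)(F)F)cc1C(=O)Nc1ccc(S(=O)(=O)N2CCCCC2C(=O)O)cc1` differs from compound 2 in one place: 2-carboxypiperidin-1-yl in place of 1H-indol-1-yl on a sulfonyl sulfur. Going by the values given here, no measured step of this kind exists, yet a shift towards lower toxicity of about a 7.7-fold higher number from compound 2 to compound 3 (0.89 log units; beyond the scatter) is expected. Compound 3 is estimated to give 100000 nM in this assay, within a range from 30000 nM to 300000 nM.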

Compound 3, half-maximal cytotoxic concentration: > 300000 nM
Compound 3 ended at the assay's limit; the forecaster's own chance of this, stated with the estimate: 40%; middle value at least 3.0-fold (0.47 log units) from the limit.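

Putting 2-carboxypiperidin-1-yl in place of 1H-indol-1-yl on the sulfonyl sulfur gives, in this assay, an at least 23-fold higher number from compound 2 to compound 3 (1.36 log units; beyond the scatter). For the compounds shown here, this is the first measured step at this position, and it shows that changing this one group can shift the read-out strongly towards lower toxicity in this test. The full size of the shift stays unknown, as compound 3 reaches a limit of the assay rather than a number: the limit of > 300000 nM in this assay, at which 2 of the 3 values shown sit.

The compounds shown do not separate the effect of replacing the aromatic rings from that of adding the carboxylic acid. Plain piperidin-1-yl, without the carboxylic acid, would tell these two apart.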